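This account rests on a few compounds, and the source may have more. Where it says the series, first, only, none or still open, it means among the compounds named here.

Compound 1 `O=C1O[C@H]([C@@H](O)Cn2cc(-c3ccc(Br)cc3)nn2)C(OCc2ccccc2)=C1OCc1ccccc1` is the anchor of this comparison. In a functional assay on HepG2 cells (Homo sapiens) for antiproliferative activity, read by MTT assay, with a stated time of 72 h (on this read-out higher numbers stand for weaker inhibition and lower numbers for stronger inhibition), compound 1 gives 5070 nM. Its closest relative among the measured compounds is compound 3 `O=C1O[C@H]([C@@H](O)Cn2cc(CNS(=O)(=O)c3ccc(Cl)cc3)nn2)C(OCc2ccccc2)=C1OCc1ccccc1`, which in this assay gives 7510 nM; the move a 1.5-fold higher number from compound 1 to compound 3 (0.17 log units; within the scatter) changes the number so little that the two compounds cannot be told apart here. Compound 2 `COc1ccc(-c2cn(C/C=C3\OC(=O)C(OCc4ccccc4)=C3OCc3ccccc3)nn2)cc1` is different in kind: in this assay compound 2 is recorded only as a limit, > 100000 nM, and not as a number. So compound 1 and compound 3 stand together as the two measured numbers, and compound 2 stands apart at a limit.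

Compound 4 `O=C1O[C@H]([C@@H](O)Cn2cc(CCCCl)nn2)C(OCc2ccccc2)=C1OCc1ccccc1` is the next step. Relative to compound 1 the change is 3-chloropropyl in place of 4-bromophenyl on an aromatic carbon. Within the data shown here, only one measured step touches the same position, and that is the move from compound 1 to compound 3, which stayed within the scatter even though the incoming group there kept a ring. The incoming 3-chloropropyl keeps no ring, so the step is not a close copy of that one. On the evidence of compound 1 at 5070 nM, compound 4 is expected to land somewhat weaker, by about a 2.4-fold higher number from compound 1 to compound 4 (0.37 log units; beyond the scatter), and compound 4 is estimated at 12000 nM, with a plausible range from 4000 nM to 40000 nM.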

Compound 4, half-maximal inhibitory concentration: 35000 nM
For compound 4 the middle estimate is 2.9-fold (0.46 log units) below the measured one, and the stated range covers the measured number.
By their numbers in this assay, from the lowest: compounds 1 and 3 (each within the scatter of the next); then compound 4. At a limit, above all of these: compound 2.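

Among these compounds, until now the only measured change at this aromatic carbon, from compound 1 to compound 3, stayed within the scatter, so the position could have seemed to accept different groups with little effect. Among the compounds shown here, the 3-chloropropyl group is the first to shift the number clearly, with a 6.9-fold higher number from compound 1 to compound 4 (0.84 log units; beyond the scatter) and a 4.7-fold higher number from compound 3 to compound 4 (0.67 log units; beyond the scatter), both modest but beyond the scatter. Among these three compounds, the two whose groups carry a six-membered aromatic ring give numbers within the scatter of each other, while the group with no ring gives the higher number, but nothing measured here shows why this change weakens inhibition.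

The comparison also leaves the loss of the ring tangled with other differences, since 3-chloropropyl differs from 4-bromophenyl in its chlorine as well as in its shape and size. A plain propyl chain, a longer chain ending in chlorine, a propyl chain ending in an amine and an unsubstituted phenyl ring would each help to show whether the ring, the halogen or the chain length governs the number at this position.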